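Adding a nitro group in place of a hydroxy group

The source may hold more compounds than are shown below. What is called first, only, known or untested is meant among the compounds shown, and "the series" means these compounds.

Values in a functional assay on PC-3 cells (Homo sapiens) for cytotoxicity, read by sulforhodamine B assay, with a stated time of 48 h; on this read-out lower numbers stand for stronger inhibition and higher numbers for weaker inhibition:
- Compound 1 `C[C@H]1CC[C@@H]2[C@@H](OC(=O)[C@]23CC(c2ccccc2)=NO3)[C@]2(C)C(=O)C=C[C@@]12O`: 46000 nM
- Compound 2 `C[C@H]1CC[C@@H]2[C@@H](OC(=O)[C@]23CC(c2ccc(O)cc2)=NO3)[C@]2(C)C(=O)C=C[C@@]12O`: 20000 nM

Of these two, compound 2 has the lower number. The move to compound 3 `C[C@H]1CC[C@@H]2[C@@H](OC(=O)[C@]23CC(c2ccccc2[N+](=O)[O-])=NO3)[C@]2(C)C(=O)C=C[C@@]12O` is 2-nitrophenyl in place of 4-hydroxyphenyl on a carbon with a double bond to nitrogen, with 2-nitrophenyl in place of 4-hydroxyphenyl on a carbon with a double bond to nitrogen. Going by the values given here, only one measured step bears on this: a 2.3-fold lower number from compound 1 to compound 2 (0.36 log units; beyond the scatter), which came with adding the hydroxy. Among the compounds with values here, compound 3 has no hydroxy, so that modest gain may be lost, although no nitro compound has yet been measured. The expected change in this assay is a 2.1-fold higher number from compound 2 to compound 3 (0.32 log units; beyond the scatter), a modest rise. For compound 3 the estimated value is 42000 nM, with an expected range of 16000 nM to 100000 nM.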

Compound 3, half-maximal inhibitory concentration: 37000 nM
Estimate against measurement, compound 3: 1.1-fold (0.06 log units) above, within the range that was stated.
By their numbers in this assay, from the lowest: compounds 2, 3 and 1 (each within the scatter of the next, the first and the last beyond it).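

In this assay, replacing 4-hydroxyphenyl with 2-nitrophenyl gives a 1.9-fold higher number from compound 2 to compound 3 (0.27 log units; within the scatter), while adding the nitro group to the unsubstituted aromatic ring gives a 1.2-fold lower number from compound 1 to compound 3 (0.09 log units; within the scatter). Compound 3 therefore cannot be told apart from either neighbour, even though those two neighbours differ from each other by more than the scatter. The nitro group thus brings no measurable gain at this position, and its value cannot settle whether the hydroxy benefit is lost. As far as these compounds go, it remains open whether an amine or a carboxylic acid on this aromatic ring would give a clearly different value. Nothing available here offers an explanation for these results.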